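Adding a Fluorine to Compound 3: an Expected Outcome

A few compounds are considered here, and "the series" means these few. Any claim that something is new, unique, unknown or untested is made for them only; others in the source may bear on it.

Compound 1, `CC(=O)OC/C(=C\c1ccc(Cl)cc1Cl)C(=O)c1ccc(Cl)cc1`: in a functional assay on HeLa cells (Homo sapiens) for inhibition, read by sulforhodamine B assay, with a stated time of 48 h (a higher number here means a weaker inhibitor of growth, a lower number a stronger inhibitor of growth), compound 1 gives 4600 nM.
Compound 2, `CC(=O)OC/C(=C/c1ccccc1[N+](=O)[O-])C(=O)c1ccccc1`: in this assay compound 2 gives 78000 nM.
Compound 3, `C=C(C/C(=C\c1ccccc1)C(=O)c1ccccc1)C(=O)c1ccccc1`: in this assay compound 3 gives 19000 nM.

Among these three numbers, compound 3 stands second highest, which here means second weakest as an inhibitor of growth. Its nearest neighbour is compound 2, whose number is higher, and its furthest is compound 1, whose number is lower; both gaps lie beyond the usual scatter of repeated measurements.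

Compound 4, `C=C(C/C(=C\c1ccc(F)cc1)C(=O)c1ccccc1)C(=O)c1ccccc1`, has not yet been measured. It differs from compound 3 by fluoro in place of hydrogen on an aromatic carbon, so the change is a single fluorine in place of a hydrogen on one aromatic ring. Among the compounds with values here, no pair of measured compounds shows this same change, so its effect cannot be read from the data given. For a change this small, the step from compound 3 to compound 4 in this assay is expected to be a 1.4-fold lower number from compound 3 to compound 4 (0.13 log units; within the scatter), most likely not beyond the scatter. Compound 4 is therefore estimated to give 14000 nM, with a likely range from 5000 nM to 40000 nM.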

Compound 4, concentration for 50% growth inhibition: 18000 nM
The estimate for compound 4 lay 1.3-fold (0.11 log units) below the measured number; the range from low to high includes it.
By their numbers in this assay, from the lowest: compound 1; then compounds 4 and 3 (each within the scatter of the next); then compound 2.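

In this assay, replacing phenyl with 4-fluorophenyl gives a 1.1-fold lower number from compound 3 to compound 4 (0.02 log units; within the scatter), so at this place, on an aromatic carbon para to a large group, a single fluorine leaves the two compounds indistinguishable. This is the only pair shown that differs in one place, which makes it the sole direct reading of a single change in this series, and it shows that this ring position tolerates fluoro without a measurable loss or gain in growth inhibition. No measurement available here explains this result.

As far as these compounds go, whether the same holds for a bigger or differently built group at this position, such as methoxy, an amine or a carboxylic acid, stays open. So does the effect of fluoro on either of the other two phenyl rings.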